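A few compounds are considered here, and "the series" means these few. Any claim that something is new, unique, unknown or untested is made for them only; others in the source may bear on it.

Compound 1 `COC(=O)C1=C(C)N=C(C)/C(=C(/O)OC)C1c1cccc(N/C(=N/CCNC2CCN(c3ccccc3OC)CC2)NC#N)c1`: in an assay on SK-N-MC cells for inhibition of Neuropeptide Y receptor type 1 (Homo sapiens) (a higher number here means a weaker inhibitor, a lower number a stronger inhibitor), compound 1 gives 4 nM.
Compound 2 `COC(=O)C1=C(C)N=C(C)/C(=C(/O)OC)C1c1cccc(N/C(=N/CCNC2CCN(c3ccccc3OC(F)(F)F)CC2)NC#N)c1`: in this assay compound 2 gives 28 nM.
Compound 3 `COC(=O)C1=C(C)N=C(C)/C(=C(/O)OC)C1c1cccc(NC(=O)NCCNC2CCN(c3ccccc3OC)CC2)c1`: in this assay compound 3 gives 2 nM.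

Compounds 1 and 2 differ in a single place: trifluoromethyl in place of methyl on an oxygen on an aromatic ring. This change produced a 7.0-fold higher number from compound 1 to compound 2 (0.85 log units; beyond the scatter). Compound 3 shares most of its structure with compound 1, but the difference between the two cores is not broken down here; the two values in this assay lie within the scatter of each other. Compound 4 `COC(=O)C1=C(C)N=C(C)/C(=C(/O)OC)C1c1cccc(NC(=O)NCCNC2CCN(c3ccccc3OC(F)(F)F)CC2)c1` has not yet been measured. It differs from compound 3 by the same change that separates compound 1 from compound 2: trifluoromethyl in place of methyl on an oxygen on an aromatic ring. Because that change once gave a 7.0-fold higher number from compound 1 to compound 2 (0.85 log units; beyond the scatter), a step of similar size is expected here, a 7.0-fold higher number from compound 3 to compound 4 (0.85 log units; beyond the scatter). The estimate for compound 4 in this assay is 14 nM, expected to fall between 5 nM and 40 nM.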

Compound 4, half-maximal inhibitory concentration: 25 nM
Compound 4: middle estimate off by 1.8-fold (0.25 log units), on the low side; the range from low to high includes it.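

Trifluoromethyl in place of methyl on the oxygen on the aromatic ring gave a 13-fold higher number from compound 3 to compound 4 (1.10 log units; beyond the scatter) in this assay, the same direction as on the core of compound 1. The two steps do not differ beyond the scatter, so between these two cores the change carried over with much the same size: the same change on two cores in this assay, a 7.0-fold higher number (0.85 log units; beyond the scatter) from compound 1 to compound 2 and a 13-fold higher number (1.10 log units; beyond the scatter) from compound 3 to compound 4, 1.8-fold (0.25 log units) apart, within the scatter of two such steps. Among the compounds shown here, this rests on only two pairs in one assay, so it does not show that the step would hold on any other core, and it does not explain the loss.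

Going by these compounds, what an ethoxy group or a chlorine atom in that place would do stays open. So does how a longer chain in the linker would alter the step.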